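A few compounds are considered here, and "the series" means these few. Any claim that something is new, unique, unknown or untested is made for them only; others in the source may bear on it.

Among the measured compounds shown here, compound 1 `O=C1/C(=C\c2ccccc2)c2c(ncn2COCc2ccccc2)CCN1Cc1ccccc1` was tested in a functional assay on A549 cells (Homo sapiens) for inhibition, read by MTT assay, with a stated time of 72 h (on this read-out lower numbers stand for stronger inhibition and higher numbers for weaker inhibition), where it gives 9900 nM, the lowest of the two numbers so far. Compound 2 `O=C1/C(=C\c2ccccc2)c2c(ncn2COCc2ccccc2)CCN1Cc1ccc(F)cc1` gives 19600 nM in this assay, and the step of a 2.0-fold higher number from compound 1 to compound 2 (0.30 log units; within the scatter) shows only a change at an aromatic carbon away from the double bond. Compound 3 `COc1cc(/C=C2\C(=O)N(Cc3ccccc3)CCc3ncn(COCc4ccccc4)c32)cc(OC)c1OC` differs from compound 1 by 3,4,5-trimethoxyphenyl in place of phenyl on a double-bonded chain carbon bound to a double-bonded ring carbon. For the measured compounds named here, no measured step touches this position, so the only guide is the scatter seen so far. Compound 3 is expected to come out near compound 1, with the step of a 2.0-fold lower number from compound 1 to compound 3 (0.30 log units; within the scatter) as a tentative guess, giving an estimate of 5000 nM within 1000 nM to 25000 nM.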

Compound 3, half-maximal inhibitory concentration: 8560 nM
Estimate against measurement, compound 3: 1.7-fold (0.23 log units) below; measured number inside the range.
By their numbers in this assay, from the lowest: compounds 3, 1 and 2 (each within the scatter of the next, the first and the last beyond it).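

Replacing phenyl with 3,4,5-trimethoxyphenyl on a double-bonded chain carbon bound to a double-bonded ring carbon gives a 1.2-fold lower number from compound 1 to compound 3 (0.06 log units; within the scatter) in this assay. Among the compounds shown here, this is the first look at this position, and it shows that a group with more heavy atoms and added oxygen atoms leaves the number within the scatter. Nothing available explains this result. As far as these compounds go, it remains open whether an amine or a carboxylic acid at this position would move the number beyond the scatter. The compounds shown also leave open whether a much smaller group, such as methyl, would do so.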